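The source may report more compounds than this note shows. Statements on the series, on what has been measured and on what is new or still open speak of the compounds shown alone.

Compound 1 `COc1ccc2nc(C)cc(OCC(=O)Nc3cc(C)cc(C)c3)c2c1` gives < 0.0834 h in an ADME assay on microsomes from liver (Mus musculus) for metabolic stability, read by LC-MS, using NADPH, with a stated time of 30 min, tested at 0.5 uM (a higher number here means that the compound lasts longer, a lower number that the compound disappears faster), which is a limit of the assay.
Compound 2 `Cc1cc(C)cc(NC(=O)COc2cc(C)nc3ccc(C)cc23)c1` gives < 0.0834 h in this assay, also a limit.

Among the compounds with values here, compound 1 thus stands only at a limit, as does the one other value shown; the limit of < 0.0834 h in this assay, at which 2 of the 2 values shown sit, sums up what is known. Within the data shown here, the single measured step, a step that the two limits leave unreadable from compound 1 to compound 2, cannot be read. Compound 3 `COc1ccc2nc(C)cc(OCC(=O)Nc3cc(C)ccc3C)c2c1` differs from compound 1 by 2,5-dimethylphenyl in place of 3,5-dimethylphenyl on an amide-type nitrogen. Among the measured compounds shown here, no measured step bears on this change, and the one step available is unreadable, so no direction beyond the scatter can be drawn. Compound 3 is expected to remain at the limit, with an estimated step that the limit leaves unreadable from compound 1 to compound 3 and an estimated half-life of 0.05 h (range 0.02 h to 0.15 h).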

Compound 3, half-life: < 0.0834 h
Compound 3 ended at the assay's limit; the forecaster's own chance of this, stated with the estimate: 80%; the middle value is on the limit's open side.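

Compound 1 and compound 3 both sit at a limit, so the step between them cannot be read. The compounds shown leave open how their true half-lives compare in this assay, where the data give only this: the limit of < 0.0834 h in this assay, at which 3 of the 3 values shown sit.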